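Swapping the oxazole for an aminophenyl on the amide carbonyl

The compounds below may be only part of what the source reports. "The series", "measured", "known", "first", "only" and "open" are said of these compounds alone.

Of the compounds shown here, three sharing one core have been measured in an assay on isolated protein for inhibition of Rho-associated protein kinase 1 (Homo sapiens), read by scintillation counting, radiometric assay and 33P incorporation, with a stated time of 40 min, in the presence of a further agent that is not named here; a lower number here means a stronger inhibitor, a higher number a weaker inhibitor. Compound 1 `CCCc1ccc(C(=O)Nc2cccc(NC(=O)COc3ccc4c(=O)ccoc4c3)c2)cc1` gives 143 nM, compound 2 `Cc1cc(C(=O)Nc2cccc(NC(=O)COc3ccc4c(=O)ccoc4c3)c2)ccc1C(F)(F)F` gives 460 nM, and compound 3 `Cc1cc(C(=O)Nc2cccc(NC(=O)COc3ccc4c(=O)ccoc4c3)c2)no1` gives 68 nM. Compound 3 therefore has the lowest number of the three, with a 2.1-fold lower number from compound 1 to compound 3 (0.32 log units; beyond the scatter) and a 6.8-fold lower number from compound 2 to compound 3 (0.83 log units; beyond the scatter). Compound 4 `Nc1ccc(C(=O)Nc2cccc(NC(=O)COc3ccc4c(=O)ccoc4c3)c2)cc1` is the next to be measured; it differs from compound 3 by 4-aminophenyl in place of 5-methyl-1,2-oxazol-3-yl on a carbonyl carbon.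

Two earlier steps bear on this change, since both replace the group on that carbonyl carbon with a six-membered carbon ring: a 2.1-fold lower number from compound 1 to compound 3 (0.32 log units; beyond the scatter) and a 6.8-fold lower number from compound 2 to compound 3 (0.83 log units; beyond the scatter) show that the two carbon-ring compounds gave higher numbers than compound 3, while a 3.2-fold higher number from compound 1 to compound 2 (0.51 log units; beyond the scatter) shows that the substituent on such a ring can shift the result by a modest amount. A modest rise from compound 3 is thus expected, as a 2.2-fold higher number from compound 3 to compound 4 (0.34 log units; beyond the scatter). Compound 4 is expected to give about 150 nM in this assay, plausibly between 50 nM and 450 nM.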

Compound 4, half-maximal inhibitory concentration: 802 nM
Estimate against measurement, compound 4: 5.3-fold (0.73 log units) below, and the stated range ends below it.
By their numbers in this assay, from the lowest: compound 3; then compound 1; then compounds 2 and 4 (each within the scatter of the next).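

The step of [ a 12-fold higher number from compound 3 to compound 4 (1.07 log units; beyond the scatter) ] is the largest seen so far at this carbonyl carbon, so the choice of group here can matter more than compound 1, compound 2 and compound 3 had indicated. With the six-membered carbon ring kept, the group on that ring also counts, since amino in place of propyl gives [ a 5.6-fold higher number from compound 1 to compound 4 (0.75 log units; beyond the scatter) ], while the change in ring substituents separating the other two carbon-ring compounds gives only [ a 1.7-fold higher number from compound 2 to compound 4 (0.24 log units; within the scatter) ]. Nothing measured here gives a reason for these shifts.

The compounds shown leave open whether compound 3 would keep its low number with hydrogen in place of the methyl on its 1,2-oxazol-3-yl ring. They also leave open how a hydroxyl or a dimethylamino group in place of the amino on the six-membered ring of compound 4 would compare.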